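The source may hold more compounds than are shown below. What is called first, only, known or untested is meant among the compounds shown, and "the series" means these compounds.

Measured compounds:
compound 1, `CCCC(=O)OCSc1ccc(OC)cc1C(=O)NCCC(N)=O`: > 100 uM
compound 2, `CCCC(=O)OCSc1ccccc1C(=O)NCCCCCNC(C)=O`: 9.2 uM

In an ADME assay on CEM-SS cells (Homo sapiens) for cytotoxicity, read by XTT assay, with a stated time of 6 days (on this read-out lower numbers stand for higher toxicity in this test and higher numbers for lower toxicity in this test), compound 2 gives 9.2 uM, the only number reported among these two compounds. Compound 1 is reported only as a limit of the assay, > 100 uM. This is the limit of > 100 uM in this assay, at which 1 of the 2 values shown sits. Compound 3, `CCCC(=O)OCSc1ccccc1C(=O)NCC(=O)NCC(N)=O`, differs from compound 2 in one place: (carbamoylmethyl)carbamoyl in place of 4-acetamidobutyl on a saturated chain carbon bound to an amide-type nitrogen. Among the measured compounds shown here, no step between measured compounds is available, so the expectation rests on this structural change alone. The step of a 4.3-fold higher number from compound 2 to compound 3 (0.64 log units; beyond the scatter) is expected to run toward lower toxicity and to exceed the usual scatter. Compound 3 is expected to give about 40 uM, with a likely range from 10 uM to 100 uM.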

Compound 3, half-maximal toxic concentration: > 100 uM
Compound 3 was reported as a limit; the forecaster's own chance of this, stated with the estimate: 40%; middle value at least 2.5-fold (0.39 log units) from the limit.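

In this assay, putting (carbamoylmethyl)carbamoyl in place of 4-acetamidobutyl gives an at least 10-fold higher number from compound 2 to compound 3 (1.03 log units; beyond the scatter), so the group at this position can strongly shift the read-out. Compound 3 gives > 100 uM, which is a limit of the assay. The full size of the step remains unknown because compound 3 sits at that limit: the limit of > 100 uM in this assay, at which 2 of the 3 values shown sit.

The compounds shown do not separate the effect of chain length from that of the added carbamoyl groups. Going by these compounds, how a terminal amine or carboxylic acid at this position would read also remains open.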